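The source may report more compounds than this note shows. Statements on the series, on what has been measured and on what is new or still open speak of the compounds shown alone.

Compound 1 `O=C(N/N=C/c1cccc(Cl)c1Cl)Nc1cc2c(Nc3ccc(F)c(Cl)c3)ncnc2cc1O[C@H]1CCOC1`: 16900 nM
Compound 2 `COc1cc2ncnc(Nc3ccc(F)c(Cl)c3)c2cc1NC(=O)N/N=C/c1ccc(F)cc1`: 31100 nM
Compound 3 `COc1cc2ncnc(Nc3ccc(F)c(Cl)c3)c2cc1NC(=O)N/N=C/c1ccc([N+](=O)[O-])cc1`: 34100 nM

All three compounds were read in a functional assay on HepG2 cells (Homo sapiens) for cytotoxicity, read by MTT assay, with a stated time of 72 h; on this read-out lower numbers stand for stronger inhibition and higher numbers for weaker inhibition. On these numbers, compound 3 lies within the scatter of both other compounds, so the set shows no separation in this assay. The next compound, compound 4 `COc1cc2ncnc(Nc3ccc(F)c(Cl)c3)c2cc1NC(=O)N/N=C/c1cccc(Cl)c1Cl`, has not yet been measured. It differs from compound 3 by one change, (2,3-dichlorophenyl in place of 4-nitrophenyl on a carbon with a double bond to nitrogen), which puts 2,3-dichlorophenyl in place of 4-nitrophenyl on a carbon with a double bond to nitrogen.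

For the measured compounds named here, only one measured step concerns a change on this aromatic ring: a 1.1-fold higher number from compound 2 to compound 3 (0.04 log units; within the scatter), with nitro in place of fluoro on an aromatic carbon, which stays within the scatter. Going by the values given here, no measured step covers the exact exchange. The closest guide is compound 1, which has 16900 nM and carries the same 2,3-dichlorophenyl on a different core. Its value stays within the scatter of compound 3, so no step beyond the scatter is expected in this assay, though a small move toward compound 1 would not be surprising. The expected change is a 1.4-fold lower number from compound 3 to compound 4 (0.13 log units; within the scatter). For compound 4 the estimated value is 25000 nM, with an expected range from 13000 nM to 45000 nM.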

Compound 4, half-maximal inhibitory concentration: 26100 nM
Compound 4: middle estimate off by 1.0-fold (0.02 log units), on the low side; low and high end bracket the measured number.
By their numbers in this assay, from the lowest: compounds 1, 4, 2 and 3 (each within the scatter of the next).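

In this assay the 2,3-dichlorophenyl group in place of 4-nitrophenyl on a carbon with a double bond to nitrogen gives a 1.3-fold lower number from compound 3 to compound 4 (0.12 log units; within the scatter) while the same group in place of 4-fluorophenyl gives a 1.2-fold lower number from compound 2 to compound 4 (0.08 log units; within the scatter) and so these three aryl groups on the shared core are not told apart at this place. For the compounds shown here, with 2,3-dichlorophenyl held fixed, methyl in place of oxolan-3-yl on an oxygen on an aromatic ring gives a 1.5-fold higher number from compound 1 to compound 4 (0.19 log units; within the scatter) and this is the first single-place comparison of those two groups, which the read-out likewise does not separate. Nothing measured alongside these numbers speaks to the reason for these results.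

All the groups shown on the carbon with a double bond to nitrogen are substituted phenyl rings, so it remains open whether a pyridine ring, a cyclohexyl ring or a longer alkyl chain there would separate from them. On the aromatic oxygen, only methyl and oxolan-3-yl are shown, which leaves open how a chain ending in an amine, such as a morpholine, would read.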